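A few compounds are considered here, and "the series" means these few. Any claim that something is new, unique, unknown or untested is made for them only; others in the source may bear on it.

Compound 2 `Cc1ccc(N(C2CCC2)S(=O)(=O)c2ccc3c(c2)C(O)CC(C2CCOCC2)O3)c(C)c1` sits second highest of the three values in a physicochemical assay for lipophilicity, at pH 7.4 (a lower number here means a more polar compound, a higher number a more lipophilic compound), where compound 2 gives 3.77; its nearest neighbour, compound 1 `CCc1ccc(N(C2CCC2)S(=O)(=O)c2ccc3c(c2)C(O)CC(C2CCOCC2)O3)cc1`, gives 3.69, and the step of a number 0.08 log units higher from compound 1 to compound 2 (within the scatter) lies within the scatter. Compound 3 `CCc1ccc(N(CC(C)C)S(=O)(=O)c2ccc(OCC3CCOCC3)c3c2CCC3O)cc1`, built on a different core, gives 4.55. Compound 4 `Cc1ccc(N(CC(C)C)S(=O)(=O)c2ccc3c(c2)C(O)CC(C2CCOCC2)O3)c(C)c1` differs from compound 2 by isobutyl in place of cyclobutyl on a sulfonamide nitrogen. No measured step among these three compounds bears directly on that swap; compound 3 carries isobutyl yet differs from compound 2 in its core as well, so its value can only hint that isobutyl sits on the higher side. A modest rise beyond the scatter is therefore expected for compound 4, with the step of a number 0.33 log units higher from compound 2 to compound 4 (beyond the scatter) in this assay. Compound 4 is accordingly estimated at 4.1, within the range 3.7 to 4.5.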

Compound 4, distribution coefficient: 4.19
Compound 4: middle estimate off by 0.09 log units, on the low side, and the stated range covers the measured number.
By their numbers in this assay, from the lowest: compounds 1 and 2 (each within the scatter of the next); then compound 4; then compound 3.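

In this assay, for the compounds shown here, the change at the sulfonamide nitrogen gives the first direct reading at this position, a number 0.42 log units higher from compound 2 to compound 4 (beyond the scatter), while the only earlier single-place step, on the other substituent of that nitrogen, stayed within the scatter. Cyclobutyl and isobutyl both hold 4 heavy atoms, all carbon, so the number moved with the ring opened and the carbon count unchanged. Nothing shown here accounts for the size of this step. Going by these compounds, whether the swap gives a similar step with 4-ethylphenyl or on the core of compound 3 remains open, as does where a longer chain or an amine on this nitrogen would fall.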